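Swapping a nitrile for a pyridine on the shared core

The compounds below may be only part of what the source reports. "The series", "measured", "known", "first", "only" and "open" are said of these compounds alone.

Measured compounds:
compound 1 `CCC(CC)CNc1c(C(N)=O)cnc2ccc(C#N)cc12` — 12 uL/min
compound 2 `C[C@@H](Nc1c(C(N)=O)cnc2ccc(C#N)cc12)c1ccc(Cl)cc1` — 10 uL/min

In an ADME assay on cells (Hepatocyte, Homo sapiens) for metabolic stability, with a stated time of 90 min (a higher number here means faster removal of the compound, a lower number slower removal), compound 1 gives 12 uL/min and compound 2 gives 10 uL/min; compound 1 holds the higher of the two numbers, but the gap to compound 2 is within the scatter, so the two cannot be told apart. Compound 3 `CCC(CC)CNc1c(C(N)=O)cnc2ccc(-c3ccc(COC)nc3)cc12` is not yet measured. It differs from compound 1 in one place: 6-(methoxymethyl)pyridin-3-yl in place of cyano on an aromatic carbon. For the measured compounds named here, no measured pair shows this kind of change, so the expected step from compound 1 to compound 3, a 2.1-fold higher number from compound 1 to compound 3 (0.32 log units; beyond the scatter), is only a rough guess, leaning toward a somewhat higher number. Compound 3 is expected to give 25 uL/min, with a range from 10 uL/min to 60 uL/min.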

Compound 3, intrinsic clearance in a liver preparation (reported as CLH), per the amount of preparation that the assay uses: < 6.8 uL/min
Compound 3 ended at the assay's limit; the forecaster's own chance of this, stated with the estimate: 5%; at least 3.6-fold (0.56 log units) between middle value and limit.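

Until now, only the nitrile had been seen at this aromatic carbon, so nothing showed how a larger group there would behave. In this assay, the 6-(methoxymethyl)pyridin-3-yl ring, with 9 heavy atoms in place of 2, gives an at least 1.7-fold lower number from compound 1 to compound 3 (0.24 log units; that floor lies within the scatter), so this larger group brings no rise in the number. The value of compound 3 is a limit of the assay and not a number: the limit of < 6.8 uL/min in this assay, at which 1 of the 3 values shown sits.

The compounds shown leave open how a plain pyridin-3-yl, a phenyl ring or an amine at this carbon would compare. They also leave open whether the same swap on compound 2 would behave alike.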